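From acetyl to bromo on the shared core

A few compounds are considered here, and "the series" means these few. Any claim that something is new, unique, unknown or untested is made for them only; others in the source may bear on it.

In an ADME assay on HEK-293T cells (Homo sapiens) for cytotoxicity, read by luminescence, with a stated time of 24 h (on this read-out lower numbers stand for higher toxicity in this test and higher numbers for lower toxicity in this test), compound 1 `CCCNC(=O)C1CCN(C(=O)c2cc3sccc3n2Cc2ccc(OC)cc2)CC1` gives 18800 nM. Compound 2 `CCCNC(=O)C1CCN(C(=O)c2cc3sc(C(=O)c4ccccc4)cc3n2Cc2ccc(OC)cc2)CC1` reads > 100000 nM, which is a limit and not a number. Compound 3 `CCCNC(=O)C1CCN(C(=O)c2cc3sc(C(C)=O)cc3n2Cc2ccc(OC)cc2)CC1` reads > 100000 nM, again only a limit. As far as these compounds go, compound 3 therefore stands at the limit of > 100000 nM in this assay, at which 2 of the 3 values shown sit, and its true value is unknown.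

Compound 4 `CCCNC(=O)C1CCN(C(=O)c2cc3sc(Br)cc3n2Cc2ccc(OC)cc2)CC1` carries bromo in place of acetyl on an aromatic carbon next to the ring sulfur (bromo in place of acetyl on an aromatic carbon).

Going by the values given here, two measured steps bear on this change: an at least 5.3-fold higher number from compound 1 to compound 3 (0.72 log units; beyond the scatter) and an at least 5.3-fold higher number from compound 1 to compound 2 (0.72 log units; beyond the scatter). Both lie beyond the scatter, but they show only what the benzoyl and acetyl groups do in place of hydrogen, and neither involves bromo. The step between the two ketones, a step that the two limits leave unreadable from compound 2 to compound 3, adds nothing further. Compound 4 is thus expected to lie between compound 1, at 18800 nM, and compound 3. The estimate means an at least 2.0-fold lower number from compound 3 to compound 4 (0.30 log units; that floor lies within the scatter), an expected move toward lower numbers in this assay. For compound 4 the estimated value is 50000 nM, with an expected range from 15000 nM to 100000 nM.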

Compound 4, half-maximal cytotoxic concentration: > 100000 nM
Compound 4 ended at the assay's limit (the forecaster's own chance of this, stated with the estimate: 35%); middle value at least 2.0-fold (0.30 log units) from the limit.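

Bromo in place of hydrogen on the aromatic carbon next to the ring sulfur gives an at least 5.3-fold higher number from compound 1 to compound 4 (0.72 log units; beyond the scatter) in this assay. The shift therefore does not depend on a carbonyl: a single bromine atom, with no hydrogen-bond acceptor, moves the read-out in the same direction as the benzoyl and acetyl groups, and no compound shown at this position goes against that. Compound 4 reads > 100000 nM, which is a limit and not a number.

As far as these compounds go, the steps among compound 2, compound 3 and compound 4 cannot be read, so the order of these three groups stays open: the limit of > 100000 nM in this assay, at which 3 of the 4 values shown sit. It also remains open whether an amine or a carboxylic acid on this carbon would shift the read-out in the same direction.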